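This account rests on a few compounds, and the source may have more. Where it says the series, first, only, none or still open, it means among the compounds named here.

- compound 1 `CCCCCCCCCCCC(=O)OC[C@H]1O[C@@H](O[C@@H]2OC=C(C(=O)OC)[C@H]3C[C@H](OC(C)=O)[C@H](C)[C@@H]23)[C@H](OC(C)=O)[C@@H](OC(C)=O)[C@@H]1OC(C)=O`: 0.85 ug/mL
- compound 2 `CCCCCCCCCCCCCCCC(=O)OC[C@H]1O[C@@H](O[C@@H]2OC=C(C(=O)OC)[C@H]3C[C@H](OC(C)=O)[C@H](C)[C@@H]23)[C@H](OC(C)=O)[C@@H](OC(C)=O)[C@@H]1OC(C)=O`: "not active" (no number reported)

Among the measured compounds shown here, in a functional assay on WRL68 cells (Homo sapiens) for cytotoxicity, read by MTT assay, with a stated time of 4 h (on this read-out higher numbers stand for weaker inhibition and lower numbers for stronger inhibition), compound 1 gives 0.85 ug/mL, the only number so far. By contrast, compound 2 is reported as "not active" (no number reported), so activity does not hold across the two measured compounds. Compound 3 `COC(=O)C1=CO[C@@H](O[C@@H]2O[C@H](COC(=O)c3cccc([N+](=O)[O-])c3)[C@@H](OC(C)=O)[C@H](OC(C)=O)[C@H]2OC(C)=O)[C@@H]2[C@@H](C)[C@@H](OC(C)=O)C[C@H]12` has 3-nitrophenyl in place of undecyl on a carbonyl carbon. For the measured compounds named here, no measured step between compounds anchors the expected size of this change. An estimated step of a 3.5-fold higher number from compound 1 to compound 3 (0.55 log units; beyond the scatter) is expected, towards weaker inhibition, with wide uncertainty. For compound 3 the estimated value is 3 ug/mL, with an expected range of 0.6 ug/mL to 20 ug/mL.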

Compound 3, half-maximal inhibitory concentration: 3.2 ug/mL
Compound 3: the middle estimate sits 1.1-fold (0.03 log units) below what was measured, within the range that was stated.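

In this assay, 3-nitrophenyl in place of undecyl on a carbonyl carbon gives a 3.8-fold higher number from compound 1 to compound 3 (0.58 log units; beyond the scatter), towards weaker inhibition. This position therefore keeps a measurable number with an aromatic ring in place of a long chain, whereas compound 2, which also bears a long chain, is reported as not active. No measured evidence accounts for the size of this step.

On these data alone, whether the step follows from the ring or from the nitro group remains open. A plain phenyl group or a hexyl chain at this position would help separate these.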